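A few compounds are considered here, and "the series" means these few. Any claim that something is new, unique, unknown or untested is made for them only; others in the source may bear on it.

Measured compounds:
compound 1 `Cc1ccc(S(=O)(=O)O[C@@H]2[C@@H](O)[C@H](n3cc(F)c(N)nc3=O)O[C@@H]2CO)cc1`, which in a functional assay on L5178Y cells (Mus musculus) for antiproliferative activity (a lower number here means a stronger inhibitor, a higher number a weaker inhibitor), gives 0.06 ug/mL
compound 2 `Cc1ccc(S(=O)(=O)O[C@@H]2[C@@H](O)[C@H](n3ccc(N)nc3=O)O[C@@H]2CO)cc1`, which in this assay gives 0.08 ug/mL
compound 3 `Nc1ccn([C@@H]2O[C@H](CO)[C@H](F)[C@H]2O)c(=O)n1`, which in this assay gives 37 ug/mL

Compound 3 stands highest of these three numbers, far beyond the scatter from both compound 2 and compound 1. Compound 4 `CS(=O)(=O)O[C@@H]1[C@@H](O)[C@H](n2ccc(N)nc2=O)O[C@@H]1CO` is derived from compound 3 by (methylsulfonyl)oxy in place of fluoro on a saturated ring carbon. Among the compounds with values here, the only measured step, a 1.3-fold higher number from compound 1 to compound 2 (0.12 log units; within the scatter), concerns the aromatic fluoro and not the saturated ring carbon, so it bears on this change only indirectly: it shows that the two tosyloxy compounds sit close together whatever the aromatic substituent. More telling are the two values of compound 2 and compound 3, which share the same base and differ in that compound 2 carries a sulfonyloxy group in place of fluoro; their numbers lie very far apart. A methylsulfonyloxy group is expected to behave like the tosyloxy group of compound 2 rather than like fluoro, so a large drop in the number is expected, a 190-fold lower number from compound 3 to compound 4 (2.27 log units; beyond the scatter). Compound 4 is therefore estimated at 0.2 ug/mL, within 0.03 ug/mL to 1.5 ug/mL.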

Compound 4, concentration for 50% inhibition: 0.07 ug/mL
Estimate against measurement, compound 4: 2.9-fold (0.46 log units) above; low and high end bracket the measured number.
By their numbers in this assay, from the lowest: compounds 1, 4 and 2 (each within the scatter of the next); then compound 3.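

In this assay, the sulfonyloxy group now has a direct single-place comparison at this saturated ring carbon: (methylsulfonyl)oxy in place of fluoro gives a 530-fold lower number from compound 3 to compound 4 (2.72 log units; beyond the scatter), a large step. The earlier sulfonyloxy compounds all carried a 4-methylphenyl group on the sulfur, and this result shows that this group is not needed to reach such low numbers, as methyl in its place gives a 1.1-fold lower number from compound 2 to compound 4 (0.06 log units; within the scatter), a step within the scatter. No measurement shown here explains the large gap between the sulfonyloxy and fluoro compounds. From the compounds shown here alone, it remains open whether a sulfonyl group must be present on this oxygen at all, for example whether a simple acetyl ester or an amine at this ring carbon would give similarly low numbers. Also open, going by these compounds, is whether a longer chain on the sulfur, such as butyl, would keep them.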